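The source may hold more compounds than are shown below. What is called first, only, known or untested is meant among the compounds shown, and "the series" means these compounds.

Measured compounds in a functional assay on HeLa cells (Homo sapiens) for antiproliferative activity, read by CCK-8 assay, with a stated time of 72 h; on this read-out higher numbers stand for weaker inhibition of growth and lower numbers for stronger inhibition of growth:

- compound 1, `CC[C@@H]1C(=O)N(C)c2cnc(Nc3ccc(S(=O)(=O)NCCO)cc3)nc2N1C1CCCC1`, gives 459 nM
- compound 2, `CC[C@@H]1C(=O)N(C)c2cnc(Nc3ccc(S(=O)(=O)NC4CCCC4)cc3)nc2N1C1CCCC1`, gives 609 nM
- compound 3, `CCC1C(=O)N(C)c2cnc(Nc3ccc(S(=O)(=O)NCCCO)cc3)nc2N1c1ccn(C)n1`, gives 23700 nM

Compound 3 carries the highest number of the three and is therefore the weakest inhibitor of growth among them; its gaps to compound 2 and to compound 1 both lie beyond the usual scatter of repeated measurements. Compound 4, `CCCCNS(=O)(=O)c1ccc(Nc2ncc3c(n2)N(c2ccn(C)n2)C(CC)C(=O)N3C)cc1`, has not yet been measured. It differs from compound 3 in a single place: methyl in place of hydroxy on a saturated chain carbon, three bonds along the chain from a sulfonamide nitrogen. Cut one bond further out, the same change reads 3-hydroxypropyl to butyl on the sulfonamide nitrogen.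

Going by the values given here, one measured step bears on this. In the step of a 1.3-fold higher number from compound 1 to compound 2 (0.12 log units; within the scatter) the group on the sulfonamide nitrogen is also exchanged, and the hydroxy leaves with it, while the number stays within the scatter. Compound 4 is therefore expected to show only a small step, a 1.1-fold lower number from compound 3 to compound 4 (0.03 log units; within the scatter), in neither direction beyond the scatter. The estimate for compound 4 in this assay is 22000 nM, between 8000 nM and 60000 nM.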

Compound 4, concentration for 50% growth inhibition: 4320 nM
The estimate for compound 4 lay 5.1-fold (0.71 log units) above the measured number; measured number below the stated range.
By their numbers in this assay, from the lowest: compounds 1 and 2 (each within the scatter of the next); then compound 4; then compound 3.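

In this assay methyl in place of hydroxy on a saturated chain carbon, three bonds along the chain from a sulfonamide nitrogen, gives a 5.5-fold lower number from compound 3 to compound 4 (0.74 log units; beyond the scatter) and so shows that going from 3-hydroxypropyl to butyl can change the number by more than the usual scatter. The earlier exchange on this nitrogen, a 1.3-fold higher number from compound 1 to compound 2 (0.12 log units; within the scatter) with cyclopentyl replacing 2-hydroxyethyl, gave no such change, so removing a hydroxy from this chain has no single effect across these two pairs. No measurement shown here explains the difference.

The compounds shown leave open whether an amine or a carboxylic acid at the end of this chain, or a longer chain such as pentyl, would move the number further. They also leave open whether butyl would give a similar step on the core of compound 1.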